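Amine variation on the shared core: estimate for compound 4

A few compounds are considered here, and "the series" means these few. Any claim that something is new, unique, unknown or untested is made for them only; others in the source may bear on it.

Values in a functional assay on MCF7 cells (Homo sapiens) for inhibition, read by sulforhodamine B assay; a lower number here means a stronger inhibitor, a higher number a weaker inhibitor:
Compound 1 `COc1cccc(NC2=CC(=O)c3c(nc4n3[C@H]3OC[C@@H](O)[C@H]3OC4)C2=O)c1`: 3830 nM
Compound 2 `Cc1ccc(NC2=CC(=O)c3c(nc4n3[C@H]3OC[C@@H](O)[C@H]3OC4)C2=O)cc1C`: 4950 nM
Compound 3 `O=C1C(NC2CC2)=CC(=O)c2c1nc1n2[C@H]2OC[C@@H](O)[C@H]2OC1`: a limit only, > 16000 nM

Compound 3 sits at the limit in this assay (the limit of > 16000 nM in this assay, at which 1 of the 3 values shown sits), so only a floor is known for it. The steps of an at least 4.1-fold higher number from compound 1 to compound 3 (0.62 log units; beyond the scatter) and an at least 3.2-fold higher number from compound 2 to compound 3 (0.50 log units; beyond the scatter) are the ones that bear on the amine position, and both show the cyclopropylamino compound as the weaker one. Compound 4 `O=C1C(N2CCCCC2)=CC(=O)c2c1nc1n2[C@H]2OC[C@@H](O)[C@H]2OC1` carries piperidin-1-yl in place of cyclopropylamino on a double-bonded ring carbon. Going by the values given here, no measured step covers a ring amine without a hydrogen-bond donor, so nothing here argues for recovery towards compounds 1 or 2. The expected step that the limit leaves unreadable from compound 3 to compound 4 is none beyond the scatter, with a limit again likely. Compound 4 is estimated at 20000 nM, within 8000 nM to 50000 nM.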

Compound 4, half-maximal inhibitory concentration: > 8000 nM
Compound 4: only a limit was reported; the forecaster's own chance of this, stated with the estimate: 60%; the middle value does not contradict the limit.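

In this assay compound 4 gives only a limit, > 8000 nM. Piperidin-1-yl reads as weaker in one comparison, an at least 2.0-fold higher number from compound 1 to compound 4 (0.31 log units; beyond the scatter), while the other, an at least 1.6-fold higher number from compound 2 to compound 4 (0.20 log units; that floor lies within the scatter), settles no order. The step between compound 3 and compound 4 cannot be read, so removing the hydrogen-bond donor on this ring carbon shows no readable effect: the limit of > 8000 nM in this assay, at which 1 of the 4 values shown sits.

On these data alone, whether a small ring amine such as pyrrolidin-1-yl or morpholin-4-yl would give a measurable value here stays open. A benzylamino group would test whether an aryl ring needs to sit directly on the amine nitrogen.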